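The source may report more compounds than this note shows. Statements on the series, on what has been measured and on what is new or still open speak of the compounds shown alone.

Working notes on the series.

Of the compounds shown here, three with the shared core have been measured in an assay on isolated protein for inhibition of DNA topoisomerase 1 (Homo sapiens), with a stated time of 30 min, tested at 20 uM; on this read-out higher numbers stand for a stronger effect at the one concentration tested and lower numbers for a weaker effect. Compound 1 `Cc1ccc2nc(-c3ccccc3N(C)C)[nH]c(=O)c2c1` gives 21.1%. Compound 3 `Cc1ccc2c(=O)[nH]c(-c3ccccc3C)nc2c1` gives 39.2%, and compound 2 `CN(C)c1ccc2nc(-c3cccc4ccccc34)[nH]c(=O)c2c1` gives 2.4%. Among these three numbers compound 1 stands second highest: compound 3 lies above it beyond the scatter, and compound 2 lies below it, also beyond the scatter.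

Compound 4 `Cc1ccc2nc(-c3ccccc3C(F)(F)F)[nH]c(=O)c2c1` has not been measured. Relative to compound 1 the change is trifluoromethyl in place of dimethylamino on an aromatic carbon. Going by the values given here, no pair of measured compounds differs in one place only, so there is no measured step of this kind to lean on; what is known is that compound 3, carrying a methyl at the same sort of place, gives 39.2%, while compound 1 gives 21.1%.

On that basis a step of no more than modest size is expected from compound 1 to compound 4 in this assay, a number 4.9 percentage points higher from compound 1 to compound 4 (within the scatter), likely within the scatter or slightly upward. Compound 4 is estimated at 26%, with a range from 5% to 50%.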

Compound 4, a percentage reported as inhibition, at one concentration (the size of the read-out at that concentration, not a potency): 21.1%
For compound 4 the middle estimate is 4.9 percentage points above the measured one, and the stated range covers the measured number.
By their numbers in this assay, from the lowest: compound 2; then compounds 1 and 4 (each within the scatter of the next); then compound 3.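

In this assay, the first step readable at this position is no change at the digits printed from compound 1 to compound 4 (within the scatter), so trifluoromethyl in place of dimethylamino on an aromatic carbon, ortho to a large group, leaves the read-out unmoved. The exchange also removes the hydrogen-bond acceptor counted on dimethylamino, and the read-out shows no shift with that loss in this one pair. No measurement of any property of these groups is available to account for this result.

From the compounds shown here alone, whether a carboxylic acid, a methoxy group or a primary amine at this place would also leave the read-out unmoved remains open. The read-out comes from a single concentration, so it shows the size of the effect of compound 1 and compound 4 at that concentration only.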